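Working notes on solubility across three analogues and one proposal

This account rests on a few compounds, and the source may have more. Where it says the series, first, only, none or still open, it means among the compounds named here.

compound 1 `Cc1cc(NCc2ccccn2)n2ncc(-c3ccc(F)cc3)c2n1`: < 5000 nM
compound 2 `Cc1cc(NCc2cccnc2)n2nc(C)c(-c3ccccc3)c2n1`: 110000 nM
compound 3 `Cc1cc(NCc2ncc[nH]2)n2nc(C)c(-c3ccccc3)c2n1`: < 5000 nM

All three were read in a physicochemical assay for solubility, read by HPLC, using the shake flask method, measured as kinetic solubility, with a stated time of 2 h, at pH 7.4; on this read-out lower numbers stand for lower solubility and higher numbers for higher solubility. For compound 1 the value < 5000 nM is a limit of the assay, not a number. Compound 2 gives 110000 nM. For compound 3 the value < 5000 nM is again a limit. Going by the values given here, the only single-point step measured is an at least 22-fold lower number from compound 2 to compound 3 (1.34 log units; beyond the scatter), a change on the saturated chain carbon bound to a nitrogen on an aromatic ring, not on the aryl group carried by the core. On these data alone, compound 1 therefore stands at the floor of the series, where the limit of < 5000 nM in this assay, at which 2 of the 3 values shown sit, places it together with compound 3, and its true number is unknown.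

Compound 4 `Cc1cc(NCc2ccccn2)n2ncc(-c3cccc(N)c3)c2n1` differs from compound 1 by 3-aminophenyl in place of 4-fluorophenyl on an aromatic carbon. Among the compounds with values here, no measured step changes this aromatic carbon, so no direct size can be borrowed; the step from compound 2 to compound 3 concerns another place. The starting point being a limit, any step read upward would be partly the limit itself. The step is expected to be an at least 1.6-fold higher number from compound 1 to compound 4 (0.20 log units; that floor lies within the scatter). Compound 4 is estimated at 8000 nM, with a range from 2000 nM to 40000 nM.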

Compound 4, solubility: 160000 nM
The estimate for compound 4 lay 20-fold (1.30 log units) below the measured number; measured number outside the range, above it.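

In this assay, 3-aminophenyl in place of 4-fluorophenyl on an aromatic carbon gives an at least 32-fold higher number from compound 1 to compound 4 (1.50 log units; beyond the scatter), the first step seen at this place; the earlier step concerned only the saturated chain carbon. The value of compound 1 is a limit, so this step is a lower bound and its true size remains unknown: the limit of < 5000 nM in this assay, at which 2 of the 4 values shown sit.
Even so, the aryl group carried by the core, and not only the group on the chain, can carry a compound off that limit.

The change replaces the fluorine with an amine and also alters the substitution on the phenyl ring, so the step cannot be divided between these two differences. On these data alone, a plain phenyl, 4-aminophenyl or 3-hydroxyphenyl group at this carbon would help separate them, and the effect of 3-aminophenyl on the core of compound 3 remains open.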